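Iodo to fluoro on the aromatic ring: compound 4

The source may report more compounds than this note shows. Statements on the series, on what has been measured and on what is new or still open speak of the compounds shown alone.

Measured so far:
compound 1 `C/C(=N/NC(=S)Nc1ccccc1I)c1ccccn1` — 6.1 nM
compound 2 `CC(=NNC(=S)Nc1cccc(I)c1)c1ccccn1` — 84 nM
compound 3 `CC(=NNC(=S)Nc1ccc(I)cc1)c1ccccn1` — 59 nM

Three iodo-bearing compounds on the shared core have been run in a functional assay on U-87MG ATCC cells (Homo sapiens) for cytotoxicity, read by MTT assay, with a stated time of 48 h; a lower number here means a stronger inhibitor, a higher number a weaker inhibitor. Compound 1 gives 6.1 nM, the lowest number of the three. Compound 3 gives 59 nM, and compound 2 gives 84 nM; both gaps to compound 1 lie beyond the scatter. Among the measured compounds shown here, no two measured compounds differ in a single place, so no direct step is known; the change to compound 4 is therefore read from the structures alone.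

Compound 4 `C/C(=N/NC(=S)Nc1ccccc1F)c1ccccn1` differs from compound 1 by fluoro in place of iodo on an aromatic carbon. A moderate loss of potency is expected, with the step of a 3.3-fold higher number from compound 1 to compound 4 (0.52 log units; beyond the scatter), since the measured set shows this position to matter. Compound 4 is expected near 20 nM, within 5 nM to 80 nM.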

Compound 4, half-maximal inhibitory concentration: 5 nM
For compound 4 the middle estimate is 4.0-fold (0.60 log units) above the measured one; low and high end bracket the measured number.
By their numbers in this assay, from the lowest: compounds 4 and 1 (each within the scatter of the next); then compounds 3 and 2 (each within the scatter of the next).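

Fluoro in place of iodo, on an aromatic carbon ortho to a large group, gives a 1.2-fold lower number from compound 1 to compound 4 (0.09 log units; within the scatter), so the low number at this place does not depend on iodo. Of the two halogens, neither can be ranked above the other in this series. Nothing available bears on why the two read alike.

From the compounds shown here alone, whether an amine, a methoxy group or a carboxylic acid at this place would keep the number stays open. Also open, going by these compounds, is whether fluoro on the other ring carbons would follow the iodo compounds.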